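The source may hold more compounds than are shown below. What is called first, only, known or untested is meant among the compounds shown, and "the series" means these compounds.

Of the compounds shown here, three sharing one core have been measured in a functional assay on HCT-116 cells (Homo sapiens) for inhibition, read by CCK-8 assay, with a stated time of 72 h, tested at 20 uM; on this read-out lower numbers stand for less inhibition of growth and higher numbers for more inhibition of growth at the one concentration tested. Compound 1 `Cc1ccc2c(c1)/C(=C\C(=O)OC(C)(C)C)C(=O)N2` gives 89.4% in this assay. Compound 2 `COc1ccc2c(c1)/C(=C\C(=O)OC(C)(C)C)C(=O)N2` gives 89.6% in this assay, and compound 3 `CC(C)(C)OC(=O)/C=C1/C(=O)Nc2c(Cl)cccc21` gives 89.5%. Compound 2 thus gives the highest of the three numbers, yet compound 3 and compound 1 both lie within the scatter of it, so the three cannot be told apart. Among the compounds with values here, the one step between compounds that differ in a single place, a number 0.2 percentage points higher from compound 1 to compound 2 (within the scatter), is itself within the scatter; for compound 3 against the other two no single-place step exists, and the values merely show the same level.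

Compound 4 `CC(C)(C)OC(=O)/C=C1/C(=O)Nc2ccc([N+](=O)[O-])cc21` has not yet been measured in this assay. It differs from compound 2 by nitro in place of methoxy on an aromatic carbon. Within the data shown here, no measured step involves a nitro group, so the only guide is the step from compound 1 to compound 2, which also exchanges one group on an aromatic carbon and stayed within the scatter, together with compound 3 sitting at the same level with a chloro group. On that basis no step beyond the scatter is expected in this assay, in either direction; the expected change is a number 1.6 percentage points lower from compound 2 to compound 4 (within the scatter). Compound 4 is therefore estimated at 88%, with a range from 78% to 95%.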

Compound 4, percent growth inhibition at one concentration: 88.1%
Compound 4: middle estimate off by 0.1 percentage points, on the low side; the measured number falls inside the stated range.
By their numbers in this assay, from the lowest: compounds 4, 1, 3 and 2 (each within the scatter of the next).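

In this assay, nitro in place of methoxy on the aromatic carbon gives a number 1.5 percentage points lower from compound 2 to compound 4 (within the scatter) and nitro in place of methyl on that same carbon gives a number 1.3 percentage points lower from compound 1 to compound 4 (within the scatter). Before compound 4, this position had been read only with methyl and methoxy; it now also carries nitro, a larger group by its heavy atoms and one with a double bond outside aromatic rings, and neither step goes beyond the scatter, so three different groups on this aromatic carbon, meta to a fused ring and para to a fused ring, cannot be told apart at the one concentration tested. No other data bear on this result, and the shared level therefore stands without any explanation.

The compounds shown leave open whether any group at this position would move the number beyond the scatter, for example an amine, a carboxylic acid or a longer chain such as butoxy. They also leave open whether compounds that cannot be separated at this single concentration would separate across a range of concentrations.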